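Dropping the Diethylamino Group: Estimating a Simpler Urea Analogue

The compounds below may be only part of what the source reports. "The series", "measured", "known", "first", "only" and "open" are said of these compounds alone.

Measured so far:
- Compound 1, `CCN(CC)Cc1ccc(NC(=O)Nc2ccc3ncnc(Nc4cccc(C(F)(F)F)c4)c3c2)cc1`, gives 2070 nM in a functional assay on A549 cells (Homo sapiens) for antiproliferative activity, read by MTT assay, with a stated time of 72 h; a lower number here means a stronger inhibitor, a higher number a weaker inhibitor.
- Compound 2, `C#Cc1cccc(Nc2ncnc3ccc(NC(=O)Nc4ccc(CN(CC)CC)cc4)cc23)c1`, gives 2250 nM in this assay.
- Compound 3, `O=C(Nc1cccc(CN2CCCCC2)c1)Nc1ccc2ncnc(Nc3cccc(C(F)(F)F)c3)c2c1`, gives 1060 nM in this assay.

Among these three numbers, compound 1 sits second highest. Its nearest neighbour is compound 2, and that single step, a 1.1-fold higher number from compound 1 to compound 2 (0.04 log units; within the scatter), is within the scatter. Compound 3 gives the lowest number, but the gap from compound 1 to compound 3 is also within the scatter, so the three values are best read as alike.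

The new compound, compound 4, `Cc1ccc(NC(=O)Nc2ccc3ncnc(Nc4cccc(C(F)(F)F)c4)c3c2)cc1`, differs from compound 1 in one place: hydrogen in place of diethylamino on a saturated chain carbon bound to an aromatic carbon. The diethylamino group leaves, and a methyl remains on the phenyl of the urea. Among the measured compounds shown here, no measured step bears directly on this change; the only measured step, from compound 1 to compound 2, concerns a different part of the molecule, and compound 3 differs from compound 1 in more than one place. For the measured compounds named here, with no step that tests the loss of diethylamino, the expectation for compound 4 rests on the narrow spread of the three measured values and must be wide. A step of a 1.5-fold higher number from compound 1 to compound 4 (0.19 log units; within the scatter) is estimated, leaning toward a weaker inhibitor but with no firm basis for a large effect. Compound 4 is therefore expected to give about 3200 nM in this assay, within a range from 1000 nM to 10000 nM.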

Compound 4, half-maximal inhibitory concentration: 4140 nM
For compound 4 the middle estimate is 1.3-fold (0.11 log units) below the measured one; measured number inside the range.
By their numbers in this assay, from the lowest: compounds 3, 1, 2 and 4 (each within the scatter of the next, the first and the last beyond it).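

In this assay, among the compounds shown here, placing hydrogen where diethylamino stood on a saturated chain carbon bound to an aromatic carbon gives a 2.0-fold higher number from compound 1 to compound 4 (0.30 log units; within the scatter), and this is the first measured step that tests this position. It shows that 4-((diethylamino)methyl)phenyl can be cut back to 4-methylphenyl, with 5 heavy atoms and 1 hydrogen-bond acceptor leaving, while the two numbers stay alike, so in this single pair the diethylamino group is not needed to keep the activity seen for compound 1. Nothing available explains this result, so it stands as an observation without a known reason.

The compounds shown leave open whether a different group on the same saturated chain carbon, such as a morpholine, a carboxylic acid or a longer alkyl chain, would give a number beyond the scatter from that of compound 1. They also leave open whether the same loss of diethylamino would give a similarly small step when ethynyl takes the place of trifluoromethyl, as it does in compound 2.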